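One Added Methyl on Two Related Cores

A few compounds are considered here, and "the series" means these few. Any claim that something is new, unique, unknown or untested is made for them only; others in the source may bear on it.

Measured compounds in this set:
compound 1, `COC1=C(C)C(=O)/C(=C(O)/C=C/c2ccc(C)cc2)C(=O)C1(C)C`, 8.2 ug/mL
compound 2, `CCc1ccc(/C=C/C(O)=C2/C(=O)C(C)=C(OC)C(C)(C)C2=O)cc1`, 15.1 ug/mL
compound 3, `CCC1=C(OC)C(CC)(CC)C(=O)C(C(=O)/C=C/c2ccc(C)cc2)=C1O`, 15 ug/mL

In a functional assay on PC-3 cells (Homo sapiens) for cytotoxicity (on this read-out higher numbers stand for an effect only at larger amounts of compound and lower numbers for an effect already at smaller amounts), compound 1 gives 8.2 ug/mL. Compound 2 gives 15.1 ug/mL, and compound 3 gives 15 ug/mL. Compound 2 differs from compound 1 by methyl in place of hydrogen on a saturated chain carbon bound to an aromatic carbon, a change that produced a 1.8-fold higher number from compound 1 to compound 2 (0.27 log units; within the scatter). Compound 3 carries a different core; the difference between the two cores is not broken down here, and its value and that of compound 2 lie close together.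

Compound 4, `CCC1=C(OC)C(CC)(CC)C(=O)C(C(=O)/C=C/c2ccc(CC)cc2)=C1O`, has not yet been tested. It differs from compound 3 by methyl in place of hydrogen on a saturated chain carbon bound to an aromatic carbon, the same change seen between compound 1 and compound 2. For compound 4 in this assay the step of a 1.3-fold higher number from compound 3 to compound 4 (0.12 log units; within the scatter) is expected, because the same change gave a 1.8-fold higher number from compound 1 to compound 2 (0.27 log units; within the scatter). Compound 4 is therefore estimated at 20 ug/mL, with a likely range from 9 ug/mL to 45 ug/mL.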

Compound 4, concentration for half-maximal effect: 15 ug/mL
Compound 4: the middle estimate sits 1.3-fold (0.12 log units) above what was measured; measured number inside the range.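

In this assay the step from 4-methylphenyl to 4-ethylphenyl gave no change at the digits printed from compound 3 to compound 4 (within the scatter) on the core of compound 3, and set beside the earlier step it shows no separable difference: the same change on two cores in this assay, a 1.8-fold higher number (0.27 log units; within the scatter) from compound 1 to compound 2 and no change at the digits printed (within the scatter) from compound 3 to compound 4, 1.8-fold (0.27 log units) apart, within the scatter of two such steps. The change therefore carries between these two cores without a gap that can be told from scatter. Going by these compounds alone, this does not show that the change is without effect, or that it would behave alike on any other core, since only two pairs stand here and neither step leaves the scatter.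

The compounds shown carry only methyl or ethyl on the phenyl ring. On these data alone, how a longer chain such as butyl, an amine or a carboxylic acid in that place would read remains open.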